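Series notes: cytotoxicity on Vero cells, chloro to fluoro

This account rests on a few compounds, and the source may have more. Where it says the series, first, only, none or still open, it means among the compounds named here.

Measured so far:
compound 1 `O=C1CSC(c2cccc(Cl)c2)N1CCN1CCCCC1`: 20%
compound 2 `O=C1CSC(c2ccccc2[N+](=O)[O-])N1CCN1CCCCC1`: 24%

Both values come from an ADME assay on Vero cells (Chlorocebus sabaeus) for cytotoxicity, read by neutral red uptake, tested at 1575 ug/mL; on this read-out higher numbers stand for a weaker effect at the one concentration tested and lower numbers for a stronger effect. Going by the values given here, compound 1 gives the smaller of the two numbers, but its gap to compound 2 lies within the usual scatter, so the two compounds cannot be told apart on this read-out, and no structural step between measured compounds is available to learn from.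

Compound 3 `O=C1CSC(c2cccc(F)c2)N1CCN1CCCCC1` has not been measured. It differs from compound 1 by fluoro in place of chloro on an aromatic carbon. Among the compounds with values here, with only two measured compounds, and those two reading alike, nothing in the data ties a change at this position to a shift in the number. The step is expected to be nil or small, no larger than the scatter, and the expected step reads a number 4 percentage points higher from compound 1 to compound 3 (within the scatter). Compound 3 is therefore estimated at 24% in this assay, with a range from 10% to 40%, the width reflecting how little the two measured compounds constrain the outcome.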

Compound 3, a percentage reported as activity, at one concentration (the size of the read-out at that concentration, not a potency): 17%
The estimate for compound 3 lay 7 percentage points above the measured number, within the range that was stated.
By their numbers in this assay, from the lowest: compounds 3, 1 and 2 (each within the scatter of the next).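

Going by these compounds alone, the step from 3-chlorophenyl to 3-fluorophenyl is the first single-place comparison, and in this assay it reads a number 3 percentage points lower from compound 1 to compound 3 (within the scatter) and so does not separate the two compounds. At this aromatic carbon, fluoro in place of chloro therefore gives no shift that can be told from the scatter, on this one read-out at the one concentration tested. No measurement at hand speaks to why the two compounds read alike.

The compounds shown leave open how this aromatic carbon responds to a group other than a halogen, such as a methoxy group, an amine or a carboxylic acid. They also leave open whether a longer chain elsewhere on the shared core would read alike, or would move the number beyond the scatter.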